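Replacing Phenoxy on a Carbonyl Carbon

A few compounds are considered here, and "the series" means these few. Any claim that something is new, unique, unknown or untested is made for them only; others in the source may bear on it.

Measured in a functional assay on blood (Homo sapiens), with a stated time of 60 min, in the presence of a further agent that is not named here; on this read-out lower numbers stand for an effect already at smaller amounts and higher numbers for an effect only at larger amounts of compound:
Compound 1 `COc1ccc(S(=O)(=O)C2(C(=O)Nc3ccccc3N)CCC3(CCNCC3)C2)cc1Cl` gives 7500 nM
Compound 2 `COc1ccc(S(=O)(=O)C2(C(=O)Oc3ccccc3)CCC3(CCNCC3)C2)cc1Cl` gives 3700 nM

Of the two measured compounds, compound 2 holds the lower number, at 3700 nM. The next change leads to compound 3 `CNC(=O)NC(=O)C1(S(=O)(=O)c2ccc(OC)c(Cl)c2)CCC2(CCNCC2)C1`, with (methylcarbamoyl)amino in place of phenoxy on a carbonyl carbon. For the measured compounds named here, only one measured step bears on it, made on the same carbonyl carbon: a 2.0-fold lower number from compound 1 to compound 2 (0.31 log units; beyond the scatter), a modest one. Both groups in that step carry a six-membered aromatic ring, whereas the entering group has no ring, so the step is only a loose guide. Going by a 2.0-fold lower number from compound 1 to compound 2 (0.31 log units; beyond the scatter), a step of similar modest size toward a higher number is expected in this assay. The expected change is a 2.2-fold higher number from compound 2 to compound 3 (0.33 log units; beyond the scatter). For compound 3 the estimated value is 8000 nM, with an expected range from 2000 nM to 30000 nM.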

Compound 3, half-maximal effective concentration: > 15000 nM
Compound 3 ended at the assay's limit; the forecaster's own chance of this, stated with the estimate: 15%; middle value at least 1.8-fold (0.27 log units) away from the limit.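

In this assay, (methylcarbamoyl)amino on this carbonyl carbon gave an at least 4.0-fold higher number from compound 2 to compound 3 (0.60 log units; beyond the scatter), which shows that this place tolerates the swap of phenoxy for a group with no ring less well than the earlier step between two ring-bearing groups suggested. The value of compound 3 is a limit of the assay and not a number: the limit of > 15000 nM in this assay, at which 1 of the 3 values shown sits. Read against the amide with the 2-aminophenyl group, the change gives an at least 2.0-fold higher number from compound 1 to compound 3 (0.30 log units; that floor lies within the scatter), a floor that lies within the scatter, so only the step from the phenoxy compound clearly separates the new group.

The compounds shown do not separate the loss of the aromatic ring from the entry of the two nitrogen atoms. From the compounds shown here alone, how a benzylamino group or a morpholine would read on this carbonyl carbon remains open.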